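Taking the Phenyl Off a Thromboxane Receptor Blocker

The source may report more compounds than this note shows. Statements on the series, on what has been measured and on what is new or still open speak of the compounds shown alone.

Compound 3 `O=C(O)CCC/C=C\CC1C2CCC(O2)C1CSCCc1ccccc1` is measured in a functional assay on a cell-free system (plasma) for inhibition of thromboxane A2 receptor (Homo sapiens) (on this read-out lower numbers stand for stronger inhibition and higher numbers for weaker inhibition), where compound 3 gives 5500 nM, the highest of the three numbers recorded. Compound 1 `CCCCCCSC[C@H]1C2CCC(O2)[C@H]1C/C=C\CCCC(=O)O` gives 3800 nM, which lies within the scatter of the value of compound 3, while compound 2 `CSCSCC1C2CCC(O2)C1C/C=C\CCCC(=O)O` gives 700 nM, a gap that is beyond the scatter. Compound 4 `CCSCC1C2CCC(O2)C1C/C=C\CCCC(=O)O` has not yet been measured. It differs from compound 3 in one place: hydrogen in place of phenyl on a saturated chain carbon, two bonds along the chain from a sulfur.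

Among the measured compounds shown here, one measured step bears on this change: a 7.9-fold higher number from compound 2 to compound 3 (0.90 log units; beyond the scatter). That step placed a benzyl where a methylsulfanyl had been and raised the number, whereas the step to compound 4 removes a phenyl, so a move in the opposite direction, toward a lower number, is the natural expectation, even though the two changes are not exact mirror images. Compound 1, with its longer chain, sits near compound 3, a reminder that taking the ring away need not bring compound 4 all the way to where compound 2 stands.

Compound 4 is therefore estimated at 1500 nM, with a range from 400 nM to 5000 nM. That estimate amounts to an expected step of a 3.7-fold lower number from compound 3 to compound 4 (0.56 log units; beyond the scatter).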

Compound 4, half-maximal inhibitory concentration: 5400 nM
Beside the measured number, compound 4's estimate is 3.6-fold (0.56 log units) below it, outside the stated range (above it).
By their numbers in this assay, from the lowest: compound 2; then compounds 1, 4 and 3 (each within the scatter of the next).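

In this assay, the phenyl on a saturated chain carbon, two bonds along the chain from a sulfur, can be replaced by hydrogen with no visible change: the data show a 1.0-fold lower number from compound 3 to compound 4 (0.01 log units; within the scatter) and so cannot tell the two groups apart at this place. The second new step, a 7.7-fold higher number from compound 2 to compound 4 (0.89 log units; beyond the scatter) with the methylsulfanyl swapped for a methyl, lies close in size to the earlier 7.9-fold higher number from compound 2 to compound 3 (0.90 log units; beyond the scatter) with benzyl in the same place. The higher number therefore appears with the ring and without it, so the earlier step cannot be read as an effect of the phenyl, and what compound 3 and compound 4 share in that comparison is the loss of the methylsulfanyl.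

Nothing measured here explains either result. From the compounds shown here alone, it stays open whether the second sulfur itself matters or the end of the chain as a whole, a question that a methoxy or an amine in the place of the methylsulfanyl would bear on.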